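Piperazin-1-yl in place of the (2-aminoethyl)amino chain

The source may hold more compounds than are shown below. What is called first, only, known or untested is meant among the compounds shown, and "the series" means these compounds.

Values in a functional assay on K562 cells (Homo sapiens) for cytotoxicity, read by fluorescence, with a stated time of 72 h; on this read-out lower numbers stand for stronger inhibition and higher numbers for weaker inhibition:
- compound 1 `CSc1nc(NCc2ccc(-c3ccccn3)cc2)c2[nH]nc(C(C)C)c2n1`: 778 nM
- compound 2 `CC(C)c1n[nH]c2c(NCc3ccc(-c4ccccn4)cc3)nc(NCCO)nc12`: 38 nM
- compound 3 `CC(C)c1n[nH]c2c(NCc3ccc(-c4ccccn4)cc3)nc(NCCN)nc12`: 63 nM

Compound 3 belongs to the closely spaced pair at the low end of the three numbers, and only compound 1 lies far from it.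

The next structure is compound 4 `CC(C)c1n[nH]c2c(NCc3ccc(-c4ccccn4)cc3)nc(N3CCNCC3)nc12`, which carries piperazin-1-yl in place of (2-aminoethyl)amino on an aromatic carbon, between two ring nitrogen atoms: piperazin-1-yl in place of (2-aminoethyl)amino on an aromatic carbon.

For the measured compounds named here, no measured step turns this chain into a ring, so the evidence is indirect. Two large steps mark the loss of methylsulfanyl: a 20-fold lower number from compound 1 to compound 2 (1.31 log units; beyond the scatter), and a 12-fold lower number from compound 1 to compound 3 (1.09 log units; beyond the scatter). Compound 4 also lacks methylsulfanyl, so a return towards the value of compound 1 is not the main expectation. Going by the values given here, the only change made on the chain itself stayed within the scatter: a 1.7-fold higher number from compound 2 to compound 3 (0.22 log units; within the scatter). Ring closure remains untested, which leaves the range wide, especially upwards.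

Expected in this assay: a 1.1-fold higher number from compound 3 to compound 4 (0.05 log units; within the scatter), with no step beyond the scatter. The estimate for compound 4 is 70 nM, with an expected range of 25 nM to 200 nM.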

Compound 4, half-maximal inhibitory concentration: 17 nM
Compound 4: middle estimate off by 4.1-fold (0.61 log units), on the high side; measured number outside the range, below it.
By their numbers in this assay, from the lowest: compound 4; then compounds 2 and 3 (each within the scatter of the next); then compound 1.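

In this assay, this position responds to ring closure: piperazin-1-yl in place of (2-aminoethyl)amino gives a step beyond the scatter (a 3.7-fold lower number from compound 3 to compound 4 (0.57 log units; beyond the scatter)), whereas the exchange of hydroxy for amino on the chain stayed within it. The ring also separates from the hydroxy chain (a 2.2-fold lower number from compound 2 to compound 4 (0.35 log units; beyond the scatter)), so compound 4 stands alone at the low end of the series, and the replacement of methylsulfanyl now reaches its largest step (a 46-fold lower number from compound 1 to compound 4 (1.66 log units; beyond the scatter)). Nothing measured here bears on why the ring differs from the open chains.

The compounds shown leave open whether the second ring nitrogen of piperazin-1-yl matters, a question that morpholin-4-yl or 4-methylpiperazin-1-yl on the same aromatic carbon would address. They also leave open how a longer chain, such as (3-aminopropyl)amino, compares with the ring.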